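A few compounds are considered here, and "the series" means these few. Any claim that something is new, unique, unknown or untested is made for them only; others in the source may bear on it.

In an ADME assay on MT4 cells (Homo sapiens) for activation, read by MTT assay (a higher number here means that more compound is tolerated, a lower number that less compound is tolerated), compound 2 (`CCc1c(C(C)c2c(F)cccc2F)nc(SC(C)CC)[nH]c1=O`) gives > 3000 nM, which is a limit of the assay and not a number. Compound 1 (`CCc1c(C(C)c2c(F)cccc2Cl)nc(SC2CCCC2)[nH]c1=O`) gives > 3000 nM, also a limit, and it carries cyclopentyl on a sulfur. Compound 2 thus stands at the limit of > 3000 nM in this assay, at which 2 of the 2 values shown sit, and no exact number is available for either compound.

The next compound to consider is compound 3 (`CCc1c(C(C)c2c(F)cccc2F)nc(SC2CCCC2)[nH]c1=O`), which has cyclopentyl in place of sec-butyl on a sulfur. Within the data shown here, no two measured compounds differ in only one place, so no measured step sets the size of this change. The expectation therefore rests on the two limits and on the presence of cyclopentyl in compound 1, and it is a cautious one. No shift beyond the usual scatter is expected in this assay, and another limit is the most likely report. The expected step is a step that the limit leaves unreadable from compound 2 to compound 3, small enough to remain within that scatter. Compound 3 is estimated at 5000 nM, with an expected range from 2000 nM to 50000 nM.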

Compound 3, half-maximal cytotoxic concentration: > 3000 nM
Compound 3: a limit, no number; the forecaster's own chance of this, stated with the estimate: 75%; the middle value is on the limit's open side.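

In this assay compound 3 gives > 3000 nM, which is a limit and not a number. Its steps from compound 2 and from compound 1 cannot be read, and all three compounds share one reading: the limit of > 3000 nM in this assay, at which 3 of the 3 values shown sit.

The compounds shown leave open how much of each is tolerated, and whether either exchange, cyclopentyl for sec-butyl on a sulfur or fluoro for chloro on an aromatic carbon, changes that at all.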